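A few compounds are considered here, and "the series" means these few. Any claim that something is new, unique, unknown or untested is made for them only; others in the source may bear on it.

Measured so far:
compound 1 `O=C(/C=C/c1ccc2c(c1)B(O)OC2)c1ccco1` — 20700 nM
compound 2 `O=C(/C=C/c1ccc2c(c1)B(O)OC2)c1ccc(Cl)cc1` — 3700 nM
compound 3 `O=C(/C=C/c1ccc2c(c1)B(O)OC2)c1ccc(Br)cc1` — 4500 nM

In a functional assay on SK-OV-3 cells (Homo sapiens) for cytotoxicity, read by MTT assay, with a stated time of 48 h (a lower number here means a stronger inhibitor, a higher number a weaker inhibitor), compound 3 gives 4500 nM, the second highest of the three numbers; the step of a 1.2-fold higher number from compound 2 to compound 3 (0.09 log units; within the scatter) lies within the scatter, while compound 1 sits well apart, as a 4.6-fold lower number from compound 1 to compound 3 (0.66 log units; beyond the scatter) shows. Going by these compounds, compound 4 `O=C(/C=C/c1ccc2c(c1)B(O)OC2)c1ccccc1F` is untested and differs from compound 3 by 2-fluorophenyl in place of 4-bromophenyl on a carbonyl carbon. For the measured compounds named here, no measured step swaps one halogen-bearing phenyl for another of a different substitution pattern. The steps that touch this carbonyl substituent are a 5.6-fold lower number from compound 1 to compound 2 (0.75 log units; beyond the scatter) and a 4.6-fold lower number from compound 1 to compound 3 (0.66 log units; beyond the scatter), both replacing a furan with a halogen-bearing phenyl, and a 1.2-fold higher number from compound 2 to compound 3 (0.09 log units; within the scatter), where bromo and chloro look alike. With a halogen-bearing phenyl kept, the number for compound 4 is expected to move only by a 1.3-fold higher number from compound 3 to compound 4 (0.12 log units; within the scatter). The estimate for compound 4 is 6000 nM, within 2500 nM to 15000 nM.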

Compound 4, half-maximal inhibitory concentration: 3700 nM
The estimate for compound 4 lay 1.6-fold (0.21 log units) above the measured number; measured number inside the range.
By their numbers in this assay, from the lowest: compounds 2, 4 and 3 (each within the scatter of the next); then compound 1.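

The readings in this assay put 2-fluorophenyl on this carbonyl carbon level with 4-bromophenyl (a 1.2-fold lower number from compound 3 to compound 4 (0.09 log units; within the scatter)) and 4-chlorophenyl (no change at the digits printed from compound 2 to compound 4 (within the scatter)). Among these three compounds, then, changing both the halogen and its place on the phenyl leaves the number within the scatter, while the gap from furan-2-yl holds for a third halogen-bearing phenyl (a 5.6-fold lower number from compound 1 to compound 4 (0.75 log units; beyond the scatter)). No evidence is available to explain these results.

Going by these compounds, whether a phenyl with no halogen would stay at this level remains open. So does the effect of a methoxy group or an amine on the phenyl.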